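Swapping a methyl for chloro on the core of compound 1

This account rests on a few compounds, and the source may have more. Where it says the series, first, only, none or still open, it means among the compounds named here.

Compound 1 `Cc1ccccc1OCC(C)O` is the most polar of the three measured compounds in a physicochemical assay for lipophilicity, measured as octanol-water partition (a lower number here means a more polar compound, a higher number a more lipophilic compound), where compound 1 gives 2.14. Compound 3 `Cc1cc(Cl)cc(C)c1OCC(O)CO` lies nearest, giving 2.76, a difference beyond the scatter, while compound 2 `Cc1cc(Cl)c(OCC(C)O)c(Cl)c1` lies furthest, giving 3.16, also beyond the scatter. Compound 4 `CC(O)COc1ccccc1Cl` has not been measured. It differs from compound 1 in a single place: chloro in place of methyl on an aromatic carbon. Among the compounds with values here, no measured pair shows this exact change, so the expectation rests on the change itself: a small rise in this assay, probably not beyond the scatter, is expected from compound 1, giving a number 0.16 log units higher from compound 1 to compound 4 (within the scatter). Compound 4 is therefore estimated at 2.3, with a range from 1.9 to 2.7.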

Compound 4, partition coefficient: 2.05
Compound 4: middle estimate off by 0.25 log units, on the high side, within the range that was stated.
By their numbers in this assay, from the lowest: compounds 4 and 1 (each within the scatter of the next); then compound 3; then compound 2.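

On this aromatic carbon, ortho to a group of 5 heavy atoms, chloro in place of methyl gives a number 0.09 log units lower from compound 1 to compound 4 (within the scatter) in this assay. Within the data shown here, this is the first pair here that differs in one place, and at this position the swap leaves the two compounds indistinguishable in this measurement. Nothing available accounts for the result.

On these data alone, whether an amine or a carboxylic acid on this same carbon would give a step beyond the scatter remains open. So does whether chloro in place of methyl behaves alike elsewhere on the core.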